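The source may report more compounds than this note shows. Statements on the series, on what has been measured and on what is new or still open speak of the compounds shown alone.

In a functional assay on RAW264.7 cells (Mus musculus) for inhibition, read by Griess assay, with stated times of 3 h and 24 h (on this read-out lower numbers stand for stronger inhibition and higher numbers for weaker inhibition), compound 2 `C=C1CCC2[C@](C)(CO)[C@H](O)CC[C@@]2(C)[C@@H]1CCOC(=O)c1ccccc1` gives > 100000 nM, which is a limit of the assay and not a number. A close relative, compound 1 `C=C1CCC2[C@](C)(CO)[C@H](O)CC[C@@]2(C)[C@@H]1CCOC(=O)c1cccnc1`, gives > 50000 nM, and this too is a limit. Among the compounds with values here, the only measured step, a step that the two limits leave unreadable from compound 1 to compound 2, places phenyl where pyridin-3-yl stood on a carbonyl carbon, so it offers no size to carry forward.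

Compound 3 `C=C1CCC2[C@](C)(CO)[C@H](O)CC[C@@]2(C)[C@@H]1CCOC(=O)c1ccc([N+](=O)[O-])cc1` matches compound 2 except in one place: nitro in place of hydrogen on an aromatic carbon. This puts nitro in place of hydrogen on an aromatic carbon, para to a large group. Within the data shown here, no measured step involves that change, so the data give no sign of how far it should move the read-out, or in which direction.

The expectation of continued weak inhibition in this assay rests on the limit of compound 2, > 100000 nM. The expected change, an at least 1.4-fold lower number from compound 2 to compound 3 (0.15 log units; that floor lies within the scatter), is only a rough estimate, and the assay may again report just a limit. For compound 3 the estimated value is 70000 nM, with an expected range from 25000 nM to 200000 nM.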

Compound 3, half-maximal inhibitory concentration: 37300 nM
Beside the measured number, compound 3's estimate is 1.9-fold (0.27 log units) above it, within the range that was stated.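

In this assay, within the data shown here, nitro on the aromatic carbon para to a large group is the first change here that gives a measured number rather than a limit, with an at least 2.6-fold lower number from compound 2 to compound 3 (0.42 log units; beyond the scatter). So this position on the phenyl ring tolerates a change that moves the read-out towards stronger inhibition, but the size shown is only a floor because compound 2 stands at a limit of the assay: the limit of > 100000 nM in this assay, at which 1 of the 3 values shown sits. The swap of the whole ring gives an at least 1.3-fold lower number from compound 1 to compound 3 (0.12 log units; that floor lies within the scatter), which does not establish a real difference from the pyridin-3-yl ester, and this too is only a floor because compound 1 stands at a limit of the assay: the limit of > 50000 nM in this assay, at which 1 of the 3 values shown sits.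

The step between compound 1 and compound 2 still cannot be read, and a single group at a single place cannot show whether the effect belongs to nitro itself or would also appear with an amine or a carboxylic acid on the same carbon. Also open, going by these compounds, is what a longer chain linking the core to the carbonyl would do to the read-out.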